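A Dibromophenol Swap in a Weakly Active Series

This account rests on a few compounds, and the source may have more. Where it says the series, first, only, none or still open, it means among the compounds named here.

Measured in a functional assay on PC-3 cells (Homo sapiens) for cytotoxicity, read by MTT assay, with a stated time of 72 h; on this read-out higher numbers stand for weaker inhibition and lower numbers for stronger inhibition:
- compound 1 `COc1cc2ncnc(Nc3ccc(F)c(Cl)c3)c2cc1NC(=O)N/N=C/c1cccc(Br)c1`: "not active" (no number reported)
- compound 2 `COc1ccc(/C=N/NC(=O)Nc2cc3c(Nc4ccc(F)c(Cl)c4)ncnc3cc2OC)cc1`: 16500 nM

Going by the values given here, compound 2 holds the only number here, since compound 1 came back without one, so there is nothing to rank it against. The next compound is compound 3 `COc1cc2ncnc(Nc3ccc(F)c(Cl)c3)c2cc1NC(=O)N/N=C/c1cc(Br)c(O)c(Br)c1`. The change is 3,5-dibromo-4-hydroxyphenyl in place of 4-methoxyphenyl on a carbon with a double bond to nitrogen. Among the compounds with values here, no step between two measured compounds exists to show how much such a swap matters, so the expectation stays cautious: no shift beyond the usual scatter in this assay, with only a slight lean toward stronger inhibition. The estimated change is a 1.7-fold lower number from compound 2 to compound 3 (0.22 log units; within the scatter). Compound 3 could also end without a number, as compound 1 did. Compound 3 is expected at 10000 nM, with an estimated range of 3000 nM to 35000 nM.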

Compound 3, half-maximal inhibitory concentration: 41500 nM
The estimate for compound 3 lay 4.2-fold (0.62 log units) below the measured number; the whole stated range lies below it.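

In this assay the change to 3,5-dibromo-4-hydroxyphenyl on a carbon with a double bond to nitrogen gives a 2.5-fold higher number from compound 2 to compound 3 (0.40 log units; beyond the scatter) and so moves toward weaker inhibition. Going by these compounds alone, this is the first sign that the group at this place can shift the read-out beyond the usual scatter, something compound 1 could not show, since steps involving it cannot be read without a number. Nothing available explains why this swap has this effect.

The step replaces the methoxy group with a hydroxyl and adds two bromines at once, so it cannot say which part of the change matters. Results for a 4-hydroxyphenyl without bromine, a 3,5-dibromophenyl without hydroxyl or a 4-aminophenyl would separate these parts, but none of these groups is among the compounds shown.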